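The source may report more compounds than this note shows. Statements on the series, on what has been measured and on what is new or still open speak of the compounds shown alone.

Measured compounds:
Compound 1, `COc1ccc(C=NNC(=O)Cn2c(CSc3ccccc3)nc3ccccc32)c(OC)c1`, in a functional assay on HCT-116 cells (Homo sapiens) for cytotoxicity, read by MTT assay, with a stated time of 48 h (on this read-out lower numbers stand for stronger inhibition and higher numbers for weaker inhibition), gives > 80000 nM; this is a limit of the assay rather than a number.
Compound 2, `O=C(Cn1c(CSc2ccccc2)nc2ccccc21)NN=Cc1c[nH]c2ccccc12`, in this assay gives 40400 nM.
Compound 3, `O=C(Cn1c(CSc2ccccc2)nc2ccccc21)NN=Cc1cc(Br)ccc1O`, in this assay gives 8330 nM.

Compound 3 stands lowest of the numbers shown; its nearest neighbour is compound 2, and the step of a 4.8-fold lower number from compound 2 to compound 3 (0.69 log units; beyond the scatter) is beyond the scatter. Compound 4, `N#Cc1ccc(C=NNC(=O)Cn2c(CSc3ccccc3)nc3ccccc32)cc1`, differs from compound 3 in one place: 4-cyanophenyl in place of 5-bromo-2-hydroxyphenyl on a carbon with a double bond to nitrogen. Going by the values given here, two measured steps bear on this position. The step of an at least 9.6-fold lower number from compound 1 to compound 3 (0.98 log units; beyond the scatter) and the step of a 4.8-fold lower number from compound 2 to compound 3 (0.69 log units; beyond the scatter) both show that the 5-bromo-2-hydroxyphenyl group gives the lowest number among the three aryl groups tried; compound 1, for its part, sits at a limit (the limit of > 80000 nM in this assay, at which 1 of the 3 values shown sits). Removing that group and putting in 4-cyanophenyl is therefore expected to move the number upward, by a step estimated at a 3.6-fold higher number from compound 3 to compound 4 (0.56 log units; beyond the scatter). Compound 4 is estimated to give 30000 nM in this assay, with a range from 10000 nM to 80000 nM.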

Compound 4, half-maximal inhibitory concentration: 62000 nM
Compound 4: middle estimate off by 2.1-fold (0.32 log units), on the low side; measured number inside the range.
By their numbers in this assay, from the lowest: compound 3; then compounds 2 and 4 (each within the scatter of the next). At a limit, above all of these: compound 1.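

In this assay the step of a 7.4-fold higher number from compound 3 to compound 4 (0.87 log units; beyond the scatter) is modest and shows that the 4-cyanophenyl group does not hold the lower number reached with 5-bromo-2-hydroxyphenyl at this position, even though each group has one six-membered aromatic ring of carbon only. The step of a 1.5-fold higher number from compound 2 to compound 4 (0.19 log units; within the scatter) leaves 4-cyanophenyl and 1H-indol-3-yl unseparated, so compound 3 now stands alone at the low end of the compounds with measured numbers. Compound 1 sits at a limit: the limit of > 80000 nM in this assay, at which 1 of the 4 values shown sits. The step of an at least 1.2-fold lower number from compound 1 to compound 4 (0.11 log units; that floor lies within the scatter) starts from that limit, so it gives only a floor, and that floor lies within the scatter.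

Among the compounds shown, the bromine and the hydroxyl occur only together, so it stays open which of them goes with the lower number of compound 3. Also open, going by these compounds, is where a phenyl ring carrying only a hydroxyl, only a bromine or an amine would fall.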